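Removing the ring chloro: the step from compound 2 to compound 3

The source may report more compounds than this note shows. Statements on the series, on what has been measured and on what is new or still open speak of the compounds shown alone.

Compound 2 `Clc1ccc(-c2csc(N/N=C/c3ccc(Cl)cc3Cl)n2)cc1` in a functional assay, read by spectrophotometry, with a stated time of 15 min, tested at 20 ug/mL (on this read-out higher numbers stand for a stronger effect at the one concentration tested and lower numbers for a weaker effect), gives 73.9%, the lower of the two measured numbers. Compound 1 `Cc1ccc(-c2csc(N/N=C/c3ccc(Cl)cc3Cl)n2)cc1` gives 86% in this assay. Among the measured compounds shown here, the only measured step is a number 12.1 percentage points lower from compound 1 to compound 2 (beyond the scatter). Compound 3 `Clc1ccc(/C=N/Nc2nc(-c3ccccc3)cs2)c(Cl)c1` differs from compound 2 by hydrogen in place of chloro on an aromatic carbon. For the measured compounds named here, no measured step removes a substituent outright, so the step from compound 1 to compound 2 is only a rough guide to size: a modest step of uncertain direction is expected, a number 3.9 percentage points lower from compound 2 to compound 3 (within the scatter). Compound 3 is therefore estimated at 70%, with a range from 55% to 85%.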

Compound 3, a percentage reported as inhibition, at one concentration (the size of the read-out at that concentration, not a potency): 76.6%
Beside the measured number, compound 3's estimate is 6.6 percentage points below it, within the range that was stated.
By their numbers in this assay, from the lowest: compounds 2, 3 and 1 (each within the scatter of the next, the first and the last beyond it).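

In this assay, the change from 4-chlorophenyl to phenyl gives a number 2.7 percentage points higher from compound 2 to compound 3 (within the scatter), so at this place, para to a large group, removing the chloro shows no step beyond the scatter. Hydrogen in place of methyl gives a number 9.4 percentage points lower from compound 1 to compound 3 (within the scatter), whereas only chloro in place of methyl, with a number 12.1 percentage points lower from compound 1 to compound 2 (beyond the scatter), lies beyond it. No measured evidence bears on this difference between the steps. Still open, from the compounds shown here alone, is how an amine, a carboxylic acid or a longer chain at this place would read, and whether any such group would move the number beyond the scatter from compound 3.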